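Piperidin-1-yl groups in place of trifluoromethyl: compound 3

The source may report more compounds than this note shows. Statements on the series, on what has been measured and on what is new or still open speak of the compounds shown alone.

Measured so far:
compound 1 `O=C(Nc1ccnnc1)c1cc(C(F)(F)F)ccc1OCc1ccccc1`: 15.9 nM
compound 2 `O=C(Nc1ccnnc1)c1cc(N2CCC(O)CC2)ccc1OCc1ccccc1`: 39.8 nM

In an assay on Sf9 cells for inhibition of Leucine-rich repeat serine/threonine-protein kinase 2 (Homo sapiens), read by TR-FRET, with stated times of 30 min and 2 h (a lower number here means a stronger inhibitor, a higher number a weaker inhibitor), compound 1 gives 15.9 nM, the lowest of the two numbers; the nearest is compound 2, which gives 39.8 nM. Going by the values given here, the only measured step, a 2.5-fold higher number from compound 1 to compound 2 (0.40 log units; beyond the scatter), is modest but beyond the scatter. Compound 3 `N#CC1CCN(c2ccc(OCc3ccccc3)c(C(=O)Nc3ccnnc3)c2)CC1` is not yet measured; it differs from compound 1 by 4-cyanopiperidin-1-yl in place of trifluoromethyl on an aromatic carbon. The change closely resembles the measured step: again a piperidin-1-yl group takes the place of trifluoromethyl on the same aromatic carbon, now carrying a nitrile rather than a hydroxyl. That step is therefore the one that bears on it, and a higher number of similar, modest size is expected, a 2.2-fold higher number from compound 1 to compound 3 (0.34 log units; beyond the scatter). For compound 3 in this assay a value of 35 nM is estimated, with a range from 12 nM to 100 nM that also allows a result within the scatter of compound 1.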

Compound 3, half-maximal inhibitory concentration: 10 nM
Compound 3: the middle estimate sits 3.5-fold (0.54 log units) above what was measured, and the stated range ends above it.
By their numbers in this assay, from the lowest: compounds 3 and 1 (each within the scatter of the next); then compound 2.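

At this aromatic carbon, a piperidin-1-yl ring is compatible with a number in the range of the trifluoromethyl parent in this assay: a 1.6-fold lower number from compound 1 to compound 3 (0.20 log units; within the scatter). The step seen earlier with the 4-hydroxypiperidin-1-yl group therefore does not hold for every piperidin-1-yl group in place of trifluoromethyl. Within the ring, the substituent on the saturated carbon separates the two piperidines, with a 4.0-fold lower number from compound 2 to compound 3 (0.60 log units; beyond the scatter) for cyano in place of hydroxy, so in these three compounds the larger change comes from that substituent rather than from replacing trifluoromethyl.

Nothing available here explains the difference between cyano and hydroxy. Going by these compounds, how an unsubstituted piperidin-1-yl group, or an amine or a carboxylic acid on that saturated ring carbon, would compare remains open.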